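Working notes on tolerability in a small series

The source may hold more compounds than are shown below. What is called first, only, known or untested is meant among the compounds shown, and "the series" means these compounds.

Measured in an ADME assay on THP-1 cells (Homo sapiens) for cytotoxicity, read by MTT assay; a lower number here means that less compound is tolerated, a higher number that more compound is tolerated:
Compound 1 `Cc1nc(-c2cccnc2)sc1-c1nnc(Cc2ccccc2)o1` gives > 100 ug/mL, a limit of the assay.
Compound 2 `Cc1nc(-c2cccnc2)sc1-c1nnc(-c2cccc(Cl)c2Cl)o1` gives > 100 ug/mL, a limit of the assay.
Compound 3 `Cc1cccc(-c2nnc(-c3sc(-c4cccnc4)nc3C)o2)c1` gives > 100 ug/mL, a limit of the assay.

Compound 3 therefore stands at the assay limit, as do the other two, which is what the limit of > 100 ug/mL in this assay, at which 3 of the 3 values shown sit, records. The steps a step that the two limits leave unreadable from compound 1 to compound 2, a step that the two limits leave unreadable from compound 1 to compound 3 and a step that the two limits leave unreadable from compound 2 to compound 3 carry no readable size for that reason. Compound 4 `Cc1nc(-c2cccnc2)sc1-c1nnc(-c2ccncc2)o1` differs from compound 3 in one place: pyridin-4-yl in place of 3-methylphenyl on an aromatic carbon. For the measured compounds named here, no measured step has a readable size, so the expected step that the limit leaves unreadable from compound 3 to compound 4 rests only on the shared limit of compounds 1, 2 and 3. Compound 4 is expected at 150 ug/mL, within 70 ug/mL to 400 ug/mL, and most likely reported again only as a limit.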

Compound 4, half-maximal cytotoxic concentration: > 100 ug/mL
Compound 4 ended at the assay's limit; the forecaster's own chance of this, stated with the estimate: 85%; the middle value lies beyond the limit too.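

Compound 4 gives > 100 ug/mL, a limit of the assay. For the compounds shown here, no step from compound 1, compound 2 or compound 3 to compound 4 can be read: the limit of > 100 ug/mL in this assay, at which 4 of the 4 values shown sit. The compounds shown leave open whether benzyl, 2,3-dichlorophenyl, 3-methylphenyl and pyridin-4-yl differ at all in the concentration tolerated.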